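Methyl in Place of Fluoro: a Small Expected Step

The compounds below may be only part of what the source reports. "The series", "measured", "known", "first", "only" and "open" are said of these compounds alone.

Compound 1 `Fc1ccc2nc(NC(=S)Nc3ccc(Cl)cc3)sc2c1` gives 48100 nM in a functional assay on B16-F10 cells (Mus musculus) for cytotoxicity, read by MTT assay, with a stated time of 48 h; on this read-out lower numbers stand for stronger inhibition and higher numbers for weaker inhibition.
Compound 2 `Fc1ccc(NC(=S)Nc2nc3ccc(F)cc3s2)cc1` gives 47700 nM in this assay.
Compound 3 `S=C(Nc1ccccc1)Nc1nc2ccccc2s1` reaches only a limit of this assay, > 50000 nM.

In this assay compound 2 stands as the lowest of the two numbers, and compound 1 lies within the scatter of it. Compound 3 gives only a limit and no number, as noted in the limit of > 50000 nM in this assay, at which 1 of the 3 values shown sits.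

Compound 4 `Cc1ccc2nc(NC(=S)Nc3ccc(F)cc3)sc2c1` differs from compound 2 in one place: methyl in place of fluoro on an aromatic carbon. Within the data shown here, the only measured step, a 1.0-fold lower number from compound 1 to compound 2 (0.00 log units; within the scatter), changes a halogen on the other ring and lies within the scatter; no measured step touches the fused ring. Compound 4 is therefore expected to sit close to compound 2, with a 1.0-fold higher number from compound 2 to compound 4 (0.00 log units; within the scatter). The estimate for compound 4 is 48000 nM, with a range from 24000 nM to 96000 nM.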

Compound 4, half-maximal inhibitory concentration: > 50000 nM
Compound 4: only a limit was reported (the forecaster's own chance of this, stated with the estimate: 35%); middle value at least 1.0-fold (0.01 log units) from the limit.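

Methyl in place of fluoro gives the first measured change on the fused ring in this assay, with an at least 1.0-fold higher number from compound 2 to compound 4 (0.02 log units; that floor lies within the scatter) as its result. Compound 4 gives a limit, not a number, so this step is only a floor: it shows neither a real loss nor that methyl and fluoro match here. Compound 4 now joins the values held at the limit: the limit of > 50000 nM in this assay, at which 2 of the 4 values shown sit.

On these data alone, how far the true value of compound 4 lies from compound 2 stays open. So does whether an amine or a carboxylic acid in this place would give a clearly different number.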